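A few compounds are considered here, and "the series" means these few. Any claim that something is new, unique, unknown or untested is made for them only; others in the source may bear on it.

Measured so far:
Compound 1 `c1csc(-c2ccccc2NCC2=NCCN2)c1`: 5.75 nM
Compound 2 `Cc1ccc(-c2ccccc2NCC2=NCCN2)o1`: 46.8 nM

In a functional assay for activation of Alpha-1B adrenergic receptor (Homo sapiens), read by calcium flux (a higher number here means that more compound is needed for the effect, a lower number that less compound is needed), compound 1 gives 5.75 nM. This is the lowest of the two numbers seen, so compound 1 needs the least compound for its effect. Compound 2, in which a 5-methylfuran-2-yl sits in place of the thiophen-2-yl, gives 46.8 nM. Among the measured compounds shown here, the only step measured between these two is an 8.1-fold higher number from compound 1 to compound 2 (0.91 log units; beyond the scatter), which shows that exchanging the five-membered aromatic ring on the shared core for another one of similar shape already costs clearly more than the usual scatter.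

Compound 3 `c1cnc(-c2ccccc2NCC2=NCCN2)nc1` has not been measured yet. It differs from compound 1 in one place: pyrimidin-2-yl in place of thiophen-2-yl on an aromatic carbon. The step from compound 1 to compound 2 is the only one that bears on this change, and it concerned the same position. Since the exchange of thiophen-2-yl for pyrimidin-2-yl is a larger change than the exchange for 5-methylfuran-2-yl, a step in this assay of at least similar size, towards a higher number, is expected: a 10-fold higher number from compound 1 to compound 3 (1.02 log units; beyond the scatter). Compound 3 is therefore estimated at 60 nM, with a range from 12 nM to 300 nM.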

Compound 3, half-maximal effective concentration: 77.6 nM
Estimate against measurement, compound 3: 1.3-fold (0.11 log units) below; low and high end bracket the measured number.
By their numbers in this assay, from the lowest: compound 1; then compounds 2 and 3 (each within the scatter of the next).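

Compound 3 shows that the loss at this place on the shared core is not limited to a five-membered replacement: in this assay, putting a six-membered aromatic ring with 2 hetero atoms in place of thiophen-2-yl gives a 13-fold higher number from compound 1 to compound 3 (1.13 log units; beyond the scatter). The replacements in compound 2 and compound 3 look quite different, yet a 1.7-fold higher number from compound 2 to compound 3 (0.22 log units; within the scatter), so this assay cannot tell them apart, and among the three groups shown only thiophen-2-yl stands apart, with the lowest number. The data at hand offer no measurement that explains what sets thiophen-2-yl apart from the other two groups.

On these data alone, it remains open whether the sulfur of thiophen-2-yl matters, since compound 2 differs from compound 1 in both its ring atom and its added methyl, and a plain furan-2-yl or a 5-methylthiophen-2-yl would be needed to separate these two changes. As far as these compounds go, it is also open how a plain phenyl or a pyridin-2-yl, with one ring nitrogen rather than two, would compare at this place, and whether either would fall nearer to compound 1 or to compound 2 and compound 3.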